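The compounds below may be only part of what the source reports. "The series", "measured", "known", "first", "only" and "open" are said of these compounds alone.

Measured compounds:
compound 1 `CC(C)(C)N(NC(=O)c1ccccc1Cl)C(=O)c1ccccc1Cl` – 331 nM
compound 2 `Cc1cccc(C(=O)NN(C(=O)c2ccccc2Cl)C(C)(C)C)c1` – 603 nM
compound 3 `CC(C)(C)N(NC(=O)c1ccc(Br)cc1)C(=O)c1ccccc1Cl` – 33.9 nM

In an assay on cells for agonist activity at ecdysone receptor (Bombyx mori), read by a luciferase reporter, with a stated time of 24 h (on this read-out lower numbers stand for an effect already at smaller amounts and higher numbers for an effect only at larger amounts of compound), compound 3 gives the lowest number of the three: a 9.8-fold lower number from compound 1 to compound 3 (0.99 log units; beyond the scatter) and an 18-fold lower number from compound 2 to compound 3 (1.25 log units; beyond the scatter), while a 1.8-fold higher number from compound 1 to compound 2 (0.26 log units; within the scatter).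

Compound 4 `CCCCCCC(=O)NN(C(=O)c1ccccc1Cl)C(C)(C)C` differs from compound 3 in one place: hexyl in place of 4-bromophenyl on a carbonyl carbon. Both measured steps at this carbonyl swap one aromatic ring for another, and each moved the number markedly; none replaces the ring with a chain, so the size of this step is uncertain. Since leaving the 4-bromophenyl of compound 3 has so far meant a clearly higher number, as in a 9.8-fold lower number from compound 1 to compound 3 (0.99 log units; beyond the scatter), compound 4 is expected to show a higher number too, an 88-fold higher number from compound 3 to compound 4 (1.95 log units; beyond the scatter). The estimate for compound 4 is 3000 nM, ranging from 400 nM to 20000 nM.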

Compound 4, half-maximal effective concentration: 741 nM
For compound 4 the middle estimate is 4.0-fold (0.61 log units) above the measured one; the measured number falls inside the stated range.
By their numbers in this assay, from the lowest: compound 3; then compounds 1, 2 and 4 (each within the scatter of the next, the first and the last beyond it).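

Hexyl shows that, in this assay, a carbonyl substituent without a ring can fall within the scatter of a ring-bearing one, with a 1.2-fold higher number from compound 2 to compound 4 (0.09 log units; within the scatter), although the 2-chlorophenyl of compound 1 keeps a modest edge, with a 2.2-fold higher number from compound 1 to compound 4 (0.35 log units; beyond the scatter). The large gap to the 4-bromophenyl remains, with a 22-fold higher number from compound 3 to compound 4 (1.34 log units; beyond the scatter), so among these four compounds the low number of compound 3 goes with that particular ring rather than with having any aromatic ring. No available evidence explains this result.

Still open, as far as these compounds go, is whether a shorter chain such as ethyl, a longer chain such as octyl, or an amine at the end of the hexyl chain would change the number. Also open, from the compounds shown here alone, is whether plain phenyl would keep the low number of compound 3 without the bromine.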